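A few compounds are considered here, and "the series" means these few. Any claim that something is new, unique, unknown or untested is made for them only; others in the source may bear on it.

Measured so far:
Compound 1, `CC(C)COC(=O)N1CCN(C(=O)c2nc(Nc3cc(C4CC4)[nH]n3)c3cc(Cl)ccc3n2)C[C@H]1C`, gives 30.7% in an assay for inhibition of serine/threonine-protein kinase PAK 4 (Homo sapiens), read by FRET and Z'-LYTE, with a stated time of 60 min, tested at 5 uM, in the presence of a further agent that is not named here; a higher number here means a stronger effect of the compound at the concentration tested, a lower number a weaker effect.
Compound 2, `C[C@@H]1CN(C(=O)c2nc(Nc3cc(C4CC4)[nH]n3)c3cc(Cl)ccc3n2)CCN1C(=O)OCc1ccccc1`, gives 74% in this assay.

Going by the values given here, compound 2 stands at the top of these two numbers: the only other measured compound, compound 1, lies well beneath it, and the step of a number 43.3 percentage points higher from compound 1 to compound 2 (beyond the scatter) is beyond the scatter of repeated measurements. The two share one core and differ only at a saturated chain carbon bound to an oxygen next to a carbonyl group, where phenyl in place of isopropyl is that single large step.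

Compound 3, `C[C@@H]1CN(C(=O)c2nc(Nc3cc(C4CC4)[nH]n3)c3cc(Cl)ccc3n2)CCN1C(=O)OCC(Cl)(Cl)Cl`, has not yet been measured. Relative to compound 2 it carries trichloromethyl in place of phenyl on a saturated chain carbon bound to an oxygen next to a carbonyl group. Among the compounds with values here, only the step of a number 43.3 percentage points higher from compound 1 to compound 2 (beyond the scatter) bears on this change, and it shows that exchanging the group at this position once gave a large step in this assay. Trichloromethyl, however, is neither of the two groups already tried, so that step gives a sense of the size of effects seen at this position but not of their direction here. The expected step is therefore a number 24 percentage points lower from compound 2 to compound 3 (beyond the scatter), with wide uncertainty. Compound 3 is estimated at 50%, within a range from 20% to 80%.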

Compound 3, a percentage reported as inhibition, at one concentration (the size of the read-out at that concentration, not a potency): 63%
Compound 3: the middle estimate sits 13 percentage points below what was measured, within the range that was stated.
By their numbers in this assay, from the lowest: compound 1; then compound 3; then compound 2.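

In this assay, going by these compounds alone, the step of a number 11 percentage points lower from compound 2 to compound 3 (beyond the scatter) shows that phenyl is not the only group at this position that gives a high reading: trichloromethyl, which has no ring, loses only a modest part of the effect. The step of a number 32.3 percentage points higher from compound 1 to compound 3 (beyond the scatter) adds to this. The earlier pair alone could have suggested that the gain over isopropyl depended on the aromatic ring, whereas here a large gain comes with no ring at all. No measurement shown here explains why the three groups fall in this order.

The three compounds do not show how a saturated ring, as in cyclohexyl, a longer chain such as n-butyl, or trifluoromethyl in the place of trichloromethyl would read on the same saturated chain carbon bound to an oxygen next to a carbonyl group. All of these readings also come from a single concentration on one shared core, so they give the size of the effect at that concentration, not a potency, and they do not show whether the same order would hold on another core.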